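The compounds below may be only part of what the source reports. "The series", "measured", "known", "first", "only" and "open" are said of these compounds alone.

Compound 1 `COc1cccc(-c2cnc(NC(=O)c3ccc(F)cc3)n2C)c1`: > 100000 nM, a limit
Compound 2 `Cn1c(-c2cccc(C#N)c2)cnc1NC(=O)c1ccc(F)cc1`: > 100000 nM, a limit
Compound 3 `COc1cccc(-c2cnc(NC(=O)c3ncc[nH]3)n2C)c1`: > 100000 nM, a limit

All three compounds were tested in a toxicity assay on THP-1 cells (Homo sapiens) for inhibition (a lower number here means that less compound is tolerated, a higher number that more compound is tolerated), and none gave a number: the evidence is the limit of > 100000 nM in this assay, at which 3 of the 3 values shown sit. Compound 3 therefore stands only at a limit, > 100000 nM, and not at a measured value.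

Compound 4 `Cn1c(-c2cccc(C#N)c2)cnc1NC(=O)c1ncc[nH]1` is reached from compound 3 by one change, cyano in place of methoxy on an aromatic carbon. Within the data shown here, two measured steps bear on it. The closest is a step that the two limits leave unreadable from compound 1 to compound 2, which makes the same exchange. The other is a step that the two limits leave unreadable from compound 1 to compound 3, which makes the exchange on the carbonyl carbon that compound 3 and compound 4 share. Neither has a readable size, so they set no direction, although neither shows any sign of toxicity appearing in this assay.

No step beyond the scatter is expected, and the expected step is a number no higher from compound 3 to compound 4 (the limit leaves the size open). Compound 4 is estimated at 100000 nM, within an expected range from 40000 nM to 150000 nM, and most likely to be reported as a limit again.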

Compound 4, half-maximal cytotoxic concentration: > 50000 nM
Compound 4 gave a limit, no number; the forecaster's own chance of this, stated with the estimate: 85%; the middle value lies beyond the limit too.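

No step can be read for compound 4: its result is a limit, as are those of compound 2 and compound 3, so neither comparison has a size. In this assay the compounds shown leave open at what concentration, if any, each becomes toxic.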